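Working notes: carbamoyl for hydroxyisopropyl in compound 1

A few compounds are considered here, and "the series" means these few. Any claim that something is new, unique, unknown or untested is made for them only; others in the source may bear on it.

Measured so far in an ADME assay on microsomes from liver (Homo sapiens) for metabolic stability; a higher number here means that the compound lasts longer, a lower number that the compound disappears faster:
compound 1 `COc1cc(OCc2csc(-c3ccc(C(C)(C)O)cc3)n2)c2cc(-c3cn4nc(OC)sc4n3)oc2c1`: 1.83 h
compound 2 `COc1cc(OCc2cccc(-c3cnc(OC)cn3)c2)c2cc(-c3cn4nc(OC)sc4n3)oc2c1`: 1.48 h

Compound 1 and compound 2 lie within the usual scatter of each other, so neither stands apart on the numbers known. Compound 3 `COc1cc(OCc2csc(-c3ccc(C(N)=O)cc3)n2)c2cc(-c3cn4nc(OC)sc4n3)oc2c1` has not been measured. It differs from compound 1 in one place: carbamoyl in place of 1-hydroxy-1-methylethyl on an aromatic carbon. Going by the values given here, both groups bring one donor and one acceptor, and nothing among the measured pair speaks for a clear shift in either direction. The step of a 1.1-fold higher number from compound 1 to compound 3 (0.04 log units; within the scatter) is expected to stay within the scatter. For compound 3 the half-life is estimated at 2 h, with a range from 1 h to 4 h.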

Compound 3, half-life: 1.38 h
The estimate for compound 3 lay 1.4-fold (0.16 log units) above the measured number; low and high end bracket the measured number.
By their numbers in this assay, from the lowest: compounds 3, 2 and 1 (each within the scatter of the next).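

In this assay, carbamoyl in place of 1-hydroxy-1-methylethyl, on the aromatic carbon para to a large group, gives a 1.3-fold lower number from compound 1 to compound 3 (0.12 log units; within the scatter). Going by these compounds alone, this is the only one-place comparison at this position, and on it the two groups cannot be told apart by half-life. No measurement on hand bears on the reason for this result.

Open, on these data alone, is whether an amine or a carboxylic acid on this carbon would move the half-life beyond the scatter. Also open, as far as these compounds go, is whether the half-life responds to this position at all, or is set by the shared core.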